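Moving the Chlorine Around the Sulfonyl-Bound Phenyl Ring

The source may report more compounds than this note shows. Statements on the series, on what has been measured and on what is new or still open speak of the compounds shown alone.

Compound 1 `CN1CCC(n2cc(S(=O)(=O)c3cccc(F)c3)c3cccnc32)C1` — 1.4 nM
Compound 2 `CN1CCC(n2cc(S(=O)(=O)c3ccccc3Cl)c3cccnc32)C1` — 2.2 nM
Compound 3 `CN1CCC(n2cc(S(=O)(=O)c3cccc(Cl)c3)c3cccnc32)C1` — 1.5 nM

All three were measured in an assay on HeLa cells for displacement of a labelled ligand from 5-hydroxytryptamine receptor 6 (Homo sapiens); on this read-out higher numbers stand for weaker inhibition and lower numbers for stronger inhibition. Compound 3 stands second highest of the three numbers, nearest to compound 1 and furthest from compound 2, though every gap lies within the scatter. Compound 4 `CN1CCC(n2cc(S(=O)(=O)c3ccc(Cl)cc3)c3cccnc32)C1` differs from compound 3 by 4-chlorophenyl in place of 3-chlorophenyl on a sulfonyl sulfur. Within the data shown here, the steps that bear on this change are the other halogen shifts on the same ring: a 1.5-fold lower number from compound 2 to compound 3 (0.17 log units; within the scatter), a 1.6-fold higher number from compound 1 to compound 2 (0.20 log units; within the scatter) and a 1.1-fold higher number from compound 1 to compound 3 (0.03 log units; within the scatter), each within the scatter. With all of those steps small, compound 4 is expected to show no step beyond the scatter, about a 1.3-fold higher number from compound 3 to compound 4 (0.12 log units; within the scatter). Compound 4 is therefore estimated at 2 nM, within a range from 0.7 nM to 6 nM.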

Compound 4, inhibition constant: 4.2 nM
Beside the measured number, compound 4's estimate is 2.1-fold (0.32 log units) below it, within the range that was stated.
By their numbers in this assay, from the lowest: compounds 1, 3, 2 and 4 (each within the scatter of the next, the first and the last beyond it).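

Placing 4-chlorophenyl on the sulfonyl sulfur gives the first steps in this set that pass the scatter, both modest: a 2.8-fold higher number from compound 3 to compound 4 (0.45 log units; beyond the scatter) and a 3.0-fold higher number from compound 1 to compound 4 (0.48 log units; beyond the scatter). The remaining step stays within the scatter, a 1.9-fold higher number from compound 2 to compound 4 (0.28 log units; within the scatter), so this change separates compound 4 only from compound 1 and compound 3. No evidence is available to account for this shift.

Going by these compounds, whether a methoxy group or a nitrile in place of the chlorine of 4-chlorophenyl would keep or widen these steps stays open.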